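A Furan for a Phenyl on a Shared Core

A few compounds are considered here, and "the series" means these few. Any claim that something is new, unique, unknown or untested is made for them only; others in the source may bear on it.

Compound 1 `COc1cc(N2C(N)=C(C#N)C(c3cccc([N+](=O)[O-])c3)C3=C2CC(C)(C)CC3=O)cc(OC)c1OC` — 30%
Compound 2 `COc1cc(N2C(N)=C(C#N)C(c3ccccc3)C3=C2CC(C)(C)CC3=O)cc(OC)c1OC` — 10%

In a functional assay on Ehrlich cells (Mus musculus) for cytotoxicity, tested at 100 ug/mL (on this read-out lower numbers stand for a weaker effect and higher numbers for a stronger effect at the one concentration tested), compound 1 gives 30% and compound 2 gives 10%. Compound 2 stands lowest of the two numbers; its nearest neighbour is compound 1, with a number 20 percentage points lower from compound 1 to compound 2 (beyond the scatter). Compound 3 `COc1cc(N2C(N)=C(C#N)C(c3ccc(C)o3)C3=C2CC(C)(C)CC3=O)cc(OC)c1OC` differs from compound 2 by 5-methylfuran-2-yl in place of phenyl on a saturated ring carbon. Within the data shown here, the single measured step, a number 20 percentage points lower from compound 1 to compound 2 (beyond the scatter), concerns a substituent on the aromatic ring and says nothing about swapping that ring for another, so no step beyond the scatter is expected, namely a number 5 percentage points higher from compound 2 to compound 3 (within the scatter). For compound 3 in this assay the estimate is 15%, between 0% and 40%.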

Compound 3, a percentage reported as activity, at one concentration (the size of the read-out at that concentration, not a potency): 50%
Estimate against measurement, compound 3: 35 percentage points below; measured number above the stated range.
By their numbers in this assay, from the lowest: compound 2; then compound 1; then compound 3.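

In this assay the substituent on the saturated ring carbon matters through the ring itself, not only through what a phenyl carries: 5-methylfuran-2-yl in place of phenyl gives a number 40 percentage points higher from compound 2 to compound 3 (beyond the scatter), and in place of 3-nitrophenyl it gives a number 20 percentage points higher from compound 1 to compound 3 (beyond the scatter). On the shared core, the furan compound thus stands above both phenyl compounds. Nothing given here accounts for this rise. The compounds shown leave open whether the furan ring or its methyl group carries the change, since they include no unsubstituted furan-2-yl. On these data alone, how a thiophene or a pyridine ring would read at this carbon also remains open.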